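Methoxy in Place of Chloro and Expected Cytotoxicity

The compounds below may be only part of what the source reports. "The series", "measured", "known", "first", "only" and "open" are said of these compounds alone.

Compound 1 `O=C(Nc1nc2ccc(Cl)cc2s1)c1cn(-c2ccccc2)nc1-c1ccccc1` in an ADME assay on HEK-293T cells (Homo sapiens) for cytotoxicity, read by MTT assay, with a stated time of 72 h (on this read-out higher numbers stand for weaker inhibition and lower numbers for stronger inhibition), gives 21300 nM. Compound 2 `COc1ccc2nc(NC(=O)c3cn(-c4ccccc4)nc3-c3ccccc3)sc2c1` differs from it by methoxy in place of chloro on an aromatic carbon. In this assay compound 2 gives only a limit of the assay, > 50000 nM. The step of an at least 2.3-fold higher number from compound 1 to compound 2 (0.37 log units; beyond the scatter) therefore rests on (the limit of > 50000 nM in this assay, at which 1 of the 3 values shown sits). Compound 3 `O=C(Nc1nc2ccc(Cl)cc2s1)c1cn(-c2ccccc2)nc1-c1ccc(Cl)cc1` differs from compound 1 by chloro in place of hydrogen on an aromatic carbon, and in this assay compound 3 gives 15700 nM, a step of a 1.4-fold lower number from compound 1 to compound 3 (0.13 log units; within the scatter). Compound 4 `COc1ccc2nc(NC(=O)c3cn(-c4ccccc4)nc3-c3ccc(Cl)cc3)sc2c1` has not been measured; it differs from compound 3 by methoxy in place of chloro on an aromatic carbon, the same change that separates compound 1 from compound 2, at the same place. The step of a 2.9-fold higher number from compound 3 to compound 4 (0.46 log units; beyond the scatter) is expected to be at least as large as an at least 2.3-fold higher number from compound 1 to compound 2 (0.37 log units; beyond the scatter), because compound 2 sits at the limit of > 50000 nM in this assay, at which 1 of the 3 values shown sits. Compound 4 is estimated at 45000 nM, within 25000 nM to 90000 nM.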

Compound 4, half-maximal inhibitory concentration: 29600 nM
Beside the measured number, compound 4's estimate is 1.5-fold (0.18 log units) above it, and the stated range covers the measured number.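

In this assay, carried to the core of compound 3, methoxy in place of chloro gives a 1.9-fold higher number from compound 3 to compound 4 (0.28 log units; within the scatter), a step that lies within the scatter, unlike the one on the core of compound 1, and the comparison stays unresolved: the same change on two cores in this assay, an at least 2.3-fold higher number (0.37 log units; beyond the scatter) from compound 1 to compound 2 and a 1.9-fold higher number (0.28 log units; within the scatter) from compound 3 to compound 4; the limit leaves it open whether they differ

Chloro in place of hydrogen gives an at least 1.6-fold lower number from compound 2 to compound 4 (0.22 log units; that floor lies within the scatter), and it fares no better when set beside its counterpart: the same change on two cores in this assay, a 1.4-fold lower number (0.13 log units; within the scatter) from compound 1 to compound 3 and an at least 1.6-fold lower number (0.22 log units; that floor lies within the scatter) from compound 2 to compound 4; the limit leaves it open whether they differ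

So the series shows neither that the change carries over at a fixed size nor that its size depends on the core, because compound 2 gives only a limit of the assay: the limit of > 50000 nM in this assay, at which 1 of the 4 values shown sits.

The compounds shown leave open what an amine or a carboxylic acid would give at the place of the methoxy. They also leave open whether a longer chain there would follow the same course on both cores.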